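Meta nitro in place of meta chloro: expected growth inhibition

A few compounds are considered here, and "the series" means these few. Any claim that something is new, unique, unknown or untested is made for them only; others in the source may bear on it.

Measured compounds:
Compound 1, `CC1=CC[C@H](C(C)(C)NC(=S)N/N=C/c2ccccc2Cl)CC1`: 66200 nM
Compound 2, `CC1=CC[C@H](C(C)(C)NC(=S)N/N=C/c2cccc(Cl)c2)CC1`: > 100000 nM (a limit of the assay)
Compound 3, `CC1=CC[C@H](C(C)(C)NC(=S)N/N=C/c2ccccc2[N+](=O)[O-])CC1`: > 100000 nM (a limit of the assay)

All three share one core and differ only in the aromatic group. In a functional assay on K562 cells (Homo sapiens) for inhibition, read by sulforhodamine B assay, with a stated time of 48 h (a higher number here means a weaker inhibitor of growth, a lower number a stronger inhibitor of growth), compound 1 gives 66200 nM. For compound 2 only a limit is reported, > 100000 nM. For compound 3 likewise only a limit is reported, > 100000 nM. The step of an at least 1.5-fold higher number from compound 1 to compound 2 (0.17 log units; that floor lies within the scatter) goes with 3-chlorophenyl in place of 2-chlorophenyl on a carbon with a double bond to nitrogen. The step of an at least 1.5-fold higher number from compound 1 to compound 3 (0.17 log units; that floor lies within the scatter) goes with nitro in place of chloro on an aromatic carbon; both limits sit at the limit of > 100000 nM in this assay, at which 2 of the 3 values shown sit.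

Compound 4, `CC1=CC[C@H](C(C)(C)NC(=S)N/N=C/c2cccc([N+](=O)[O-])c2)CC1`, is not yet measured. It differs from compound 2 by nitro in place of chloro on an aromatic carbon, the same kind of change as from compound 1 to compound 3, though there the place is ortho to a large group and here meta to a large group. The expectation rests on the limit seen for compound 2, > 100000 nM. It also rests on the step of an at least 1.5-fold higher number from compound 1 to compound 3 (0.17 log units; that floor lies within the scatter). Compound 4 is therefore expected to give 150000 nM, an expected step that the limit leaves unreadable from compound 2 to compound 4, most likely again only a limit.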

Compound 4, concentration for total growth inhibition: > 100000 nM
Compound 4: no number, only a limit; the forecaster's own chance of this, stated with the estimate: 80%; the middle value does not contradict the limit.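

Compound 4 gives only a limit, as compound 2 does, so no step can be read between compound 2 and compound 4: the limit of > 100000 nM in this assay, at which 3 of the 4 values shown sit.

The compounds shown leave open whether nitro in place of chloro, meta to a large group, changes growth inhibition at all.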